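A Silicon-Bearing Group Replaces 3-Hydroxyphenyl in Compound 3

A few compounds are considered here, and "the series" means these few. Any claim that something is new, unique, unknown or untested is made for them only; others in the source may bear on it.

In a functional assay on A549 cells (Homo sapiens) for antiproliferative activity, read by MTT assay, with a stated time of 72 h (on this read-out lower numbers stand for stronger inhibition and higher numbers for weaker inhibition), compound 1 `CC(C)(C)c1cn(C[C@H](O)[C@H]2OC(=O)C(OCc3ccccc3)=C2OCc2ccccc2)nn1` gives 34000 nM. Compound 3 `O=C1O[C@H]([C@@H](O)Cn2cc(-c3cccc(O)c3)nn2)C(OCc2ccccc2)=C1OCc1ccccc1` gives 59900 nM in the same assay, the higher of the two numbers recorded here, with compound 1 as its nearest neighbour; the step of a 1.8-fold higher number from compound 1 to compound 3 (0.25 log units; within the scatter) stays within the scatter. Compound 2 `O=C1O/C(=C\Cn2cc(-c3cc(F)cc(F)c3)nn2)C(OCc2ccccc2)=C1OCc1ccccc1` reaches only > 100000 nM in this assay, which is a limit of the assay and not a number (the limit of > 100000 nM in this assay, at which 1 of the 3 values shown sits).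

Compound 4 `C[Si](C)(C)c1cn(C[C@H](O)[C@H]2OC(=O)C(OCc3ccccc3)=C2OCc2ccccc2)nn1` differs from compound 3 by a group of 4 heavy atoms (3 carbon, 1 silicon; no ring) in place of a group of 7 heavy atoms (6 carbon, 1 oxygen; one six-membered aromatic ring of carbon only), on an aromatic carbon. Within the data shown here, the only measured step that bears on this exchange is the one from compound 1 to compound 3, where tert-butyl gave way to 3-hydroxyphenyl without moving beyond the scatter. The entering group, like tert-butyl in compound 1, has no ring and no hydrogen-bond donor or acceptor, so compound 4 is expected to sit near the value of compound 1, 34000 nM, rather than to show a step beyond the scatter. Compound 4 is therefore estimated at 38000 nM in this assay, between 15000 nM and 95000 nM, an expected step of a 1.6-fold lower number from compound 3 to compound 4 (0.20 log units; within the scatter).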

Compound 4, half-maximal inhibitory concentration: 19200 nM
Beside the measured number, compound 4's estimate is 2.0-fold (0.30 log units) above it; measured number inside the range.
By their numbers in this assay, from the lowest: compounds 4, 1 and 3 (each within the scatter of the next, the first and the last beyond it). At a limit, above all of these: compound 2.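

Among these compounds, on the aromatic carbon of the five-membered ring, the silicon-bearing group gives the first step at this position in this assay that lies beyond the scatter (a 3.1-fold lower number from compound 3 to compound 4 (0.49 log units; beyond the scatter)). Set against tert-butyl, the step stays within the scatter (a 1.8-fold lower number from compound 1 to compound 4 (0.25 log units; within the scatter)), so these two ring-free groups cannot be told apart here, although only compound 4 stands clear of compound 3. Nothing measured among these compounds says why the silicon-bearing group reads this way. Because compound 3 carries both an aromatic ring and a hydroxyl group, the compounds shown cannot separate the two, and an unsubstituted phenyl at this carbon would bear on that. On these data alone, how an amine or a longer alkyl chain would read there also remains open.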